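The source may hold more compounds than are shown below. What is called first, only, known or untested is meant among the compounds shown, and "the series" means these compounds.

Measured compounds:

- compound 1, `Cc1ccc(-c2nc3sccn3c2/C=N/OCc2ccc(Cl)c(Cl)c2)cc1`: 490 nM
- compound 2, `Clc1ccc(CO/N=C/c2c(-c3ccc(-c4ccccc4)cc3)nc3sccn23)cc1Cl`: "not active" (no number reported)
- compound 3, `Clc1ccccc1CO/N=C/c1c(-c2ccc3ccccc3c2)nc2occn12`: 1100 nM

All three were tested in an assay on HepG2 cells for agonist activity at nuclear receptor subfamily 1 group I member 3 (Homo sapiens), read by a luciferase reporter, with a stated time of 23 h; a higher number here means that more compound is needed for the effect, a lower number that less compound is needed. Compound 1 gives the lowest of the two numbers reported, 490 nM. Compound 3, which carries a naphthalen-2-yl group on a different core and a different benzyl group, gives a higher number, 1100 nM, and that gap lies beyond the usual scatter. With a biphenyl group on the same core as compound 1, compound 2 is reported only as "not active" (no number reported), with no number attached.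

The unmeasured compound 4, `Clc1ccc(CO/N=C/c2c(-c3ccc4ccccc4c3)nc3sccn23)cc1Cl`, differs from compound 1 in one place:

naphthalen-2-yl in place of 4-methylphenyl on an aromatic carbon

Among the compounds with values here, no pair of measured compounds that differs in only one place is available, so the size of this step has to be judged from the surrounding numbers. Compound 3 shows that a naphthalen-2-yl group on a related scaffold gives 1100 nM, and compound 2 shows that a larger aromatic group on the same core gives "not active" (no number reported). On that basis a moderate rise in the number is expected for compound 4, a step of a 1.8-fold higher number from compound 1 to compound 4 (0.26 log units; within the scatter) in this assay. Compound 4 is therefore estimated at 900 nM, with a range from 300 nM to 3000 nM.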

Compound 4, half-maximal effective concentration: 380 nM
Compound 4: middle estimate off by 2.4-fold (0.37 log units), on the high side; low and high end bracket the measured number.
By their numbers in this assay, from the lowest: compounds 4 and 1 (each within the scatter of the next); then compound 3.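

In this assay, placing naphthalen-2-yl instead of 4-methylphenyl on this aromatic carbon gives a 1.3-fold lower number from compound 1 to compound 4 (0.11 log units; within the scatter), so the two compounds cannot be told apart. This position therefore accepts a second six-membered aromatic ring and a rise from 7 to 10 heavy atoms in the group, with the effect still present at a number close to that of compound 1. The "not active" result for compound 2, which has a biphenyl group on the same core and reads "not active" (no number reported) in this assay, therefore does not extend to every larger all-carbon aromatic group at this place, and nothing measured here explains why these groups differ.

All the groups shown at this position are aromatic and made of carbon only, so it remains open how the number would respond to an amine, a carboxylic acid or a longer chain there. Compound 3 differs from compound 4 in both the core and the benzyl group, so the separate contribution of each of these two changes also remains unresolved.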